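Bromo to Trifluoromethyl on the Aryl Ether Ring

The source may hold more compounds than are shown below. What is called first, only, known or untested is meant among the compounds shown, and "the series" means these compounds.

Compound 1 `Cc1cccc(OC2CCN(c3ccc(-n4ccnc4)nn3)CC2)c1`: 251 nM
Compound 2 `Brc1cccc(OC2CCN(c3ccc(-n4ccnc4)nn3)CC2)c1`: 23 nM

Of the compounds shown here, two have been measured in an assay on microsomes from liver for inhibition of acyl-CoA desaturase 1 (Rattus norvegicus); a higher number here means a weaker inhibitor, a lower number a stronger inhibitor. Compound 1 gives 251 nM in this assay, and compound 2 gives 23 nM. Among the measured compounds shown here, the one measured step between them, an 11-fold lower number from compound 1 to compound 2 (1.04 log units; beyond the scatter), is the only comparison available. Compound 2 therefore stands at the lowest of the two numbers, with compound 1 as its nearest neighbour, the gap being that same step.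

Compound 3 `FC(F)(F)c1cccc(OC2CCN(c3ccc(-n4ccnc4)nn3)CC2)c1` differs from compound 2 by trifluoromethyl in place of bromo on an aromatic carbon. For the measured compounds named here, no measured step exchanges bromo for trifluoromethyl, so the step of an 11-fold lower number from compound 1 to compound 2 (1.04 log units; beyond the scatter) bears on it only indirectly: it shows that the number in this assay responds strongly to what sits at this aromatic carbon, but it does not say how bromo and trifluoromethyl compare. The expectation for compound 3 is therefore a number close to that of compound 2, with a small rise the more likely direction, and the step of a 1.5-fold higher number from compound 2 to compound 3 (0.18 log units; within the scatter) is estimated to lie within or only just beyond the scatter. Compound 3 is estimated at 35 nM, within the range 9 nM to 140 nM.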

Compound 3, half-maximal inhibitory concentration: 19 nM
Compound 3: the middle estimate sits 1.8-fold (0.27 log units) above what was measured, within the range that was stated.
By their numbers in this assay, from the lowest: compounds 3 and 2 (each within the scatter of the next); then compound 1.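

In this assay, trifluoromethyl in place of bromo on this aromatic carbon gives a step that lies within the scatter (a 1.2-fold lower number from compound 2 to compound 3 (0.08 log units; within the scatter)), so the two groups cannot be told apart here, even though trifluoromethyl brings 4 heavy atoms where bromo brings 1. Measured against methyl, trifluoromethyl gives a large step beyond the scatter (a 13-fold lower number from compound 1 to compound 3 (1.12 log units; beyond the scatter)), so two different replacements of methyl now arrive at numbers within the scatter of each other, and among the three groups seen on this carbon, methyl alone stands apart. Nothing available gives a reason for this agreement between bromo and trifluoromethyl, or for the distance of both from methyl.

The compounds shown leave open how this carbon responds to other groups, such as chloro, methoxy, a nitrile, an amine or a carboxylic acid, and whether any of them would move the number away from that of compound 2 and compound 3. They also leave open whether the same groups would give the same result on other carbons of this ring, since all three compounds carry their group meta to a large group.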